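Removing a Methyl from an Oxygen in Two Series

This account rests on a few compounds, and the source may have more. Where it says the series, first, only, none or still open, it means among the compounds named here.

Compound 1 `C=CC(=O)N(CC(=O)OC)c1nc(-c2ccccc2)cs1` was tested in a functional assay on HT-29 cells (Homo sapiens) for antiproliferative activity, read by MTT assay, with a stated time of 72 h; on this read-out lower numbers stand for stronger inhibition and higher numbers for weaker inhibition. There compound 1 gives > 30000 nM, which is a limit of the assay rather than a number. Compound 2 `C=CC(=O)N(CC(=O)O)c1nc(-c2ccccc2)cs1` differs from it by hydrogen in place of methyl on an oxygen next to a carbonyl group. In this assay compound 2 gives > 30000 nM, again a limit. Between the two lies a step that the two limits leave unreadable from compound 1 to compound 2. Compound 3 `C=CC(=O)N(Cc1cc(C)no1)c1nc(-c2ccccc2OC)cs1` carries a core whose difference from compound 1 is not broken down here. In this assay compound 3 gives > 30000 nM, a limit as well. Indeed (the limit of > 30000 nM in this assay, at which 3 of the 3 values shown sit). Compound 4 `C=CC(=O)N(Cc1cc(C)no1)c1nc(-c2ccccc2O)cs1` is not yet measured and differs from compound 3 by hydrogen in place of methyl on an oxygen on an aromatic ring; this is the same kind of change as that from compound 1 to compound 2, though the place differs: on an oxygen on an aromatic ring whose other neighbours are aromatic carbon, rather than on an oxygen next to a carbonyl group whose other neighbours are carbonyl carbon. The step that the limit leaves unreadable from compound 3 to compound 4 is expected to be small, resting on compound 3 sitting at > 30000 nM. Compound 4 is therefore estimated at 40000 nM, within 15000 nM to 100000 nM, and is expected to come back as a limit.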

Compound 4, half-maximal inhibitory concentration: > 30000 nM
Compound 4: a limit, no number; the forecaster's own chance of this, stated with the estimate: 85%; the middle value lies beyond the limit too.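

No new step can be read from compound 3 to compound 4, as both stand at a limit in this assay: (the limit of > 30000 nM in this assay, at which 4 of the 4 values shown sit). The compounds shown leave open whether hydrogen in place of methyl on an oxygen changes this read-out at all.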